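From hydroxy to methoxy on compound 1

The source may report more compounds than this note shows. Statements on the series, on what has been measured and on what is new or still open speak of the compounds shown alone.

In a functional assay on NCI/ADR-RES cells (Homo sapiens) for inhibition, read by sulforhodamine B assay, with a stated time of 48 h (on this read-out higher numbers stand for weaker inhibition of growth and lower numbers for stronger inhibition of growth), compound 1 `O=C(Nc1cccc(-n2cc(-c3ccncc3)c(-c3ccc(Cl)c(O)c3)n2)c1)Nc1cccc(C(F)(F)F)c1` gives > 32500 nM, which is a limit of the assay and not a number. On these data alone, it therefore stands at the limit of > 32500 nM in this assay, at which 1 of the 2 values shown sits, so its true position is unknown.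

Compound 2 `COc1cc(-c2nn(-c3cccc(NC(=O)c4cccc(C(F)(F)F)c4)c3)cc2-c2ccncc2)ccc1Cl`, which carries the 4-chloro-3-methoxyphenyl group, gives a real number, 3170 nM.

Compound 3 `COc1cc(-c2nn(-c3cccc(NC(=O)Nc4cccc(C(F)(F)F)c4)c3)cc2-c2ccncc2)ccc1Cl` departs from compound 1 in one place, where the 4-chloro-3-hydroxyphenyl becomes 4-chloro-3-methoxyphenyl: methyl in place of hydrogen on an oxygen on an aromatic ring. For the measured compounds named here, no measured pair shows this change on its own, so any expectation is tentative. Compound 3 carries the same group as compound 2, which reads 3170 nM in this assay, so a move toward stronger inhibition of growth is expected. The expected size of this move is an at least 7.2-fold lower number from compound 1 to compound 3 (0.85 log units; beyond the scatter), although a second limit remains possible. For compound 3 the estimated value is 4500 nM, with an expected range from 1300 nM to 22000 nM.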

Compound 3, concentration for total growth inhibition: 3640 nM
The estimate for compound 3 lay 1.2-fold (0.09 log units) above the measured number; the measured number falls inside the stated range.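

Methyl in place of hydrogen on the oxygen moves the read-out in this assay from a limit to a real number, an at least 8.9-fold lower number from compound 1 to compound 3 (0.95 log units; beyond the scatter), so this position responds to the change. The size of that step remains a lower bound, since one end of it rests on a limit: the limit of > 32500 nM in this assay, at which 1 of the 3 values shown sits. Once the 4-chloro-3-methoxyphenyl group is present, (3-(trifluoromethyl)phenyl)amino in place of 3-(trifluoromethyl)phenyl on a carbonyl carbon leaves the two compounds within the scatter of each other, a 1.1-fold higher number from compound 2 to compound 3 (0.06 log units; within the scatter).

On these data alone, how far compound 1 truly lies from compound 3 stays open. The compounds shown also do not tell how an ethoxy group or a longer chain on that oxygen would read, or whether the hydroxy group would again reach the limit on the core of compound 2.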